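Swapping chloro for 2-hydroxyethoxy on the core of compound 1

The source may hold more compounds than are shown below. What is called first, only, known or untested is meant among the compounds shown, and "the series" means these compounds.

Going by the values given here, in a functional assay on B16 cells (Mus musculus) for cytotoxicity, read by CCK-8 assay, with a stated time of 24 h (a lower number here means a stronger inhibitor, a higher number a weaker inhibitor), compound 1 (`COc1ccc(-c2nc(N)c(Oc3ccccc3OC)c(Cl)n2)cc1`) gives 47800 nM, the highest of the three numbers so far. Compound 2 (`COc1ccccc1Oc1c(N)nc(-c2ccc(Br)cc2)nc1Cl`) gives 4440 nM and compound 3 (`COc1ccccc1Oc1c(N)nc(-c2ccc(I)cc2)nc1Cl`) gives 5400 nM. Bromo in place of methoxy gives an 11-fold lower number from compound 1 to compound 2 (1.03 log units; beyond the scatter), and iodo in place of methoxy gives an 8.9-fold lower number from compound 1 to compound 3 (0.95 log units; beyond the scatter). Iodo in place of bromo gives a 1.2-fold higher number from compound 2 to compound 3 (0.09 log units; within the scatter).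

Compound 4 (`COc1ccc(-c2nc(N)c(Oc3ccccc3OC)c(OCCO)n2)cc1`) keeps the 4-methoxyphenyl group of compound 1 and carries 2-hydroxyethoxy in place of chloro on an aromatic carbon. Compounds 1, 2 and 3 all carry the chloro, so the large and modest steps above were taken elsewhere on the molecule and none of them measures this change. With no direct evidence, no step beyond the scatter is expected in this assay, and the estimate stays close to compound 1 at 47800 nM, with a wide range. The expected change is a 1.2-fold higher number from compound 1 to compound 4 (0.06 log units; within the scatter). Compound 4 is estimated at 55000 nM, with an expected range of 15000 nM to 200000 nM.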

Compound 4, half-maximal inhibitory concentration: 18100 nM
For compound 4 the middle estimate is 3.0-fold (0.48 log units) above the measured one; low and high end bracket the measured number.
By their numbers in this assay, from the lowest: compounds 2 and 3 (each within the scatter of the next); then compound 4; then compound 1.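

In this assay, the position held by chloro on the core of compound 1 responds to change: 2-hydroxyethoxy in place of chloro gives a 2.6-fold lower number from compound 1 to compound 4 (0.42 log units; beyond the scatter) and so moves the number down, not up. Going by these compounds alone, the earlier steps all left the chloro in place, so this is the only reading at this position, and here the longer group with its hydrogen-bond donor costs nothing in this assay. Nothing measured here bears on the reason for this step.

As far as these compounds go, whether the same swap carries over to the bromo compound 2 or the iodo compound 3 remains open. Also open, from the compounds shown here alone, is what the step depends on, which a plain ethoxy group, a 2-aminoethoxy chain or a longer hydroxyalkoxy chain at this position could help to separate.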